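Pyrrolidine to piperidine on the ethyl chain: two pairs

The source may report more compounds than this note shows. Statements on the series, on what has been measured and on what is new or still open speak of the compounds shown alone.

Four compounds share a common framework and differ at the chain amine or at the aryl end. Compound 1 `CN(c1cccc2ccccc12)S(=O)(=O)c1ccc2c(c1)sc(=O)n2CCN1CCCC1` and compound 2 `CN(c1cccc2ccccc12)S(=O)(=O)c1ccc2c(c1)sc(=O)n2CCN1CCCCC1` form one pair; compound 3 `O=c1sc2cc(S(=O)(=O)Nc3ccccc3)ccc2n1CCN1CCCC1` and compound 4 `O=c1sc2cc(S(=O)(=O)Nc3ccccc3)ccc2n1CCN1CCCCC1` form the other. The difference between the core of compound 1 and the core of compound 3 is not broken down here.

In an ADME assay on SH-SY5Y cells (Homo sapiens) for inhibition, read by MTT assay, with a stated time of 72 h (a higher number here means a weaker inhibitor, a lower number a stronger inhibitor), compound 1 gives 102000 nM, and compound 2 gives 91900 nM. The change between them, (piperidin-1-yl in place of pyrrolidin-1-yl on a saturated chain carbon, two bonds along the chain from an aromatic nitrogen), produced a 1.1-fold lower number from compound 1 to compound 2 (0.05 log units; within the scatter). Compound 3 gives 10000 nM in this assay, the lowest number of the three, beyond the scatter against both compound 1 and compound 2.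

For the measured compounds named here, compound 4 is the only unmeasured member. It carries the same change relative to compound 3 as compound 2 carries relative to compound 1: piperidin-1-yl in place of pyrrolidin-1-yl on a saturated chain carbon, two bonds along the chain from an aromatic nitrogen. The two place descriptions read alike, so this is the same change made on a different core. Because a 1.1-fold lower number from compound 1 to compound 2 (0.05 log units; within the scatter) was found, the step from compound 3 to compound 4 is expected to be small, and nothing among the three measured compounds argues that the second core should respond differently. The expected step is no change at the digits printed from compound 3 to compound 4 (within the scatter), which is an estimate resting on that single precedent.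

Compound 4 is therefore expected to come in near 10000 nM in this assay, with an estimated range from 4000 nM to 25000 nM.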

Compound 4, half-maximal inhibitory concentration: 17400 nM
Estimate against measurement, compound 4: 1.7-fold (0.24 log units) below; the measured number falls inside the stated range.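

In this assay, the new step reads a 1.7-fold higher number from compound 3 to compound 4 (0.24 log units; within the scatter), so piperidin-1-yl in place of pyrrolidin-1-yl on a saturated chain carbon stays within the scatter on the core of compound 3, as it does on the core of compound 1. Set side by side, the two steps cannot be told apart: the same change on two cores in this assay, a 1.1-fold lower number (0.05 log units; within the scatter) from compound 1 to compound 2 and a 1.7-fold higher number (0.24 log units; within the scatter) from compound 3 to compound 4, 1.9-fold (0.29 log units) apart, within the scatter of two such steps. On this evidence, the change can be carried between these two cores with no shift expected in this assay, but the finding rests on two pairs, says nothing about any other core or read-out, and cannot exclude a small real difference hidden within the scatter.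

The compounds shown leave open whether other amines on the ethyl chain, such as morpholine or dimethylamine, or a longer chain carrying pyrrolidin-1-yl or piperidin-1-yl, would also stay within the scatter of these compounds. Also open is which part of the difference between the core of compound 1 and the core of compound 3 accounts for the gap in their printed values, as no compound shown separates the parts of that difference.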